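Series notes: aryl substituent swap on the benzylamide side

The compounds below may be only part of what the source reports. "The series", "measured", "known", "first", "only" and "open" are said of these compounds alone.

Of the compounds shown here, two have been measured in an assay on cells for antagonist activity at transient receptor potential cation channel subfamily V member 1 (Homo sapiens), read by FLIPR and calcium flux, with a stated time of 6 min; on this read-out higher numbers stand for weaker inhibition and lower numbers for stronger inhibition. Compound 1 `CC(C(=O)NCc1ccc(C(C)(C)C)nc1OCc1ccccc1)c1ccc(NS(C)(=O)=O)c(F)c1` gives 4.4 nM. Compound 2 `CC(C(=O)NCc1ccc(C(C)(C)C)cc1N1CCCC1)c1ccc(NS(C)(=O)=O)c(F)c1` gives 8.1 nM. The two values lie within the scatter of each other, so compound 2 stands level with compound 1 on the numbers shown, and no difference between them can be read. Among the measured compounds shown here, no single-point step between measured compounds is available, so the size of effect of a change at this position of the shared core is not yet known from the data.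

Compound 3 `CC(C(=O)NCc1ccc(C(C)(C)C)cc1SC1CCCCC1)c1ccc(NS(C)(=O)=O)c(F)c1` differs from compound 2 in one place: cyclohexylsulfanyl in place of pyrrolidin-1-yl on an aromatic carbon. The group that enters sits ortho to a large group and meta to a tert-butyl group, as does the group that leaves. For the measured compounds named here, both compounds measured so far carry a substituent of comparable bulk at this position and give close values, so the step from compound 2 to compound 3 is expected to be small, a 1.2-fold higher number from compound 2 to compound 3 (0.09 log units; within the scatter), not beyond the scatter. In this assay compound 3 is therefore estimated at 10 nM, with a range from 3 nM to 35 nM.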

Compound 3, inhibition constant: 7.4 nM
For compound 3 the middle estimate is 1.4-fold (0.13 log units) above the measured one; low and high end bracket the measured number.
By their numbers in this assay, from the lowest: compounds 1, 3 and 2 (each within the scatter of the next).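

In this assay, among the compounds shown here, cyclohexylsulfanyl in place of pyrrolidin-1-yl on this aromatic carbon gives a 1.1-fold lower number from compound 2 to compound 3 (0.04 log units; within the scatter), the only step so far that isolates a change at one place. This position, ortho to a large group and meta to a tert-butyl group, therefore accepts a six-membered non-aromatic ring of carbon only in place of a five-membered non-aromatic ring with 1 hetero atom, with the exchange of the linking nitrogen for sulfur and no difference beyond the scatter on this read-out. No measurement at hand accounts for this result.

As far as these compounds go, all of this rests on a single pair of ring-bearing groups, so it remains open whether a primary amine, a carboxylic acid or a small methyl group on the same carbon would read in the same range. Compound 1 differs from compound 2 and from compound 3 in more than one place, so the contribution of its benzyloxy group cannot be separated from that of the other differences.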